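One Methoxy Group Less: From Compound 2 to Compound 3

The source may hold more compounds than are shown below. What is called first, only, known or untested is meant among the compounds shown, and "the series" means these compounds.

Of the compounds shown here, two have been measured. Compound 1 `COc1ccc(-c2cc(/C=C/C(=O)c3ccc(N)cc3)[nH]n2)cc1` and compound 2 `COc1cc(-c2cc(/C=C/C(=O)c3ccc(N)cc3)[nH]n2)cc(OC)c1OC` share a common core and differ only in the number of methoxy groups on one ring. In a functional assay on SW-620 cells (Homo sapiens) for cytotoxicity, read by sulforhodamine B assay, with a stated time of 48 h, tested at 0.01 uM (a higher number here means a weaker effect of the compound at the concentration tested, a lower number a stronger effect), compound 1 gives 100%. In this assay compound 2 gives 95%. Compound 2 holds the lower of the two numbers, yet its nearest neighbour, compound 1, sits only a few points away, within the scatter, so the two read as alike at this concentration.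

Compound 3 `COc1ccc(-c2cc(/C=C/C(=O)c3ccc(N)cc3)[nH]n2)cc1OC` has not yet been measured. It differs from compound 2 in one place: hydrogen in place of methoxy on an aromatic carbon. Within the data shown here, no step between measured compounds covers this exact change. Given that compound 1 with 100% and compound 2 with 95% lie within the scatter of each other, the expected step in this assay is a number 2 percentage points higher from compound 2 to compound 3 (within the scatter), that is, none beyond the scatter. Compound 3 is therefore estimated at 97%, with a range from 85% to 105%.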

Compound 3, a percentage reported as activity, at one concentration (the size of the read-out at that concentration, not a potency): 99%
Beside the measured number, compound 3's estimate is 2 percentage points below it, within the range that was stated.
By their numbers in this assay, from the lowest: compounds 2, 3 and 1 (each within the scatter of the next).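

Hydrogen in place of methoxy on this aromatic carbon, ortho to a methoxy group and meta to a large group, gives a number 4 percentage points higher from compound 2 to compound 3 (within the scatter) in this assay and thus provides a single-place step that compound 1 and compound 2, which differ in more than one place, could not provide. Methoxy in place of hydrogen on an aromatic carbon gives a number 1 percentage points lower from compound 1 to compound 3 (within the scatter) in the same assay, so neither single change separates the compounds it joins at the one concentration tested. Nothing at hand offers an explanation for these small steps.

Among these compounds, what an amine, a carboxylic acid or a longer chain such as ethoxy would give on this aromatic carbon stays open, since methoxy and hydrogen are the only two groups compared there. Also open, going by these compounds, is whether compound 1, compound 2 and compound 3 would stay this close at other concentrations or on other cells, as this single read-out at one concentration gives no potency for any of them.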